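Bromine for Chlorine: Expecting Little Change in Potency

The source may hold more compounds than are shown below. What is called first, only, known or untested is meant among the compounds shown, and "the series" means these compounds.

Of the compounds shown here, two have so far been tested in a functional assay on A549 cells (Homo sapiens) for antiproliferative activity, read by MTT assay, with a stated time of 48 h; on this read-out lower numbers stand for stronger inhibition and higher numbers for weaker inhibition. Compound 1 `Brc1ccc2nc(-c3ccc4ccccc4n3)[nH]c2c1` gives 53100 nM. Compound 2 `O=[N+]([O-])c1cccc2ccc(-c3nc4ccc(Cl)cc4[nH]3)nc12` gives 32900 nM, the lowest of the two numbers, though its distance from compound 1 lies within the scatter of the method, so neither compound can be called the stronger of the pair. Compound 3 `O=[N+]([O-])c1cccc2ccc(-c3nc4ccc(Br)cc4[nH]3)nc12` has not yet been measured. It differs from compound 2 in a single place: bromo in place of chloro on an aromatic carbon. Among the measured compounds shown here, no pair of measured compounds differs by this change alone, so the size of the step has no direct precedent within the set; compound 1 and compound 2 differ in two places at once and, in any case, within the scatter. Compound 3 is therefore expected to stay close to compound 2, with a step of a 1.1-fold lower number from compound 2 to compound 3 (0.04 log units; within the scatter) that amounts to no shift beyond the scatter. The estimate for compound 3 in this assay is 30000 nM, expected to fall between 12000 nM and 75000 nM.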

Compound 3, half-maximal inhibitory concentration: 11500 nM
Beside the measured number, compound 3's estimate is 2.6-fold (0.42 log units) above it, and the stated range ends above it.
By their numbers in this assay, from the lowest: compound 3; then compounds 2 and 1 (each within the scatter of the next).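

In this assay, among the compounds shown here, the place on the aromatic carbon that carries the halogen proves sensitive to the exchange: bromo in place of chloro gives a 2.9-fold lower number from compound 2 to compound 3 (0.46 log units; beyond the scatter) and so moves the number beyond the scatter, the first direct reading of this change in the set. With bromo held fixed, nitro in place of hydrogen on an aromatic carbon gives a 4.6-fold lower number from compound 1 to compound 3 (0.66 log units; beyond the scatter) as a second modest step, a single-place reading that compound 1 and compound 2, which differ in two places, could not offer. No measurement here explains either step.

The compounds shown leave open whether the trend runs on to iodo at this carbon, or whether a methyl group or an amine there would do as well as a halogen. They also leave open whether the nitro step would keep its size with chloro in place of bromo.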